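A few compounds are considered here, and "the series" means these few. Any claim that something is new, unique, unknown or untested is made for them only; others in the source may bear on it.

Of the compounds shown here, three have so far been measured in a functional assay on HCT-116 cells (Homo sapiens) for antiproliferative activity, read by CCK-8 assay, with a stated time of 72 h; a lower number here means a stronger inhibitor, a higher number a weaker inhibitor. Compound 1, `Nc1ccccc1NC(=O)c1ccc(Cn2cnc3c(Nc4ccccc4)nc(Cl)nc32)cc1`, gives 1070 nM. Compound 2, `Nc1ccccc1NC(=O)c1ccc(Cn2cnc3c(Nc4ccc(-c5ccccn5)cc4)nc(Cl)nc32)cc1`, differs from it by pyridin-2-yl in place of hydrogen on an aromatic carbon and gives 1250 nM. Compound 3, `Nc1ccccc1NC(=O)c1ccc(COCNc2nc(Nc3ccccc3)c3ncn(C4CCCC4)c3n2)cc1`, rests on a different core and gives 960 nM. Among these three numbers compound 1 stands second highest; it lies nearest to compound 3 and furthest from compound 2, yet both gaps fall within the usual scatter, so no order among the three can be read from them.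

Compound 4, `CC1CCN(c2nc(Cl)nc3c2ncn3Cc2ccc(C(=O)Nc3ccccc3N)cc2)CC1`, is compound 1 with a single change: 4-methylpiperidin-1-yl in place of anilino on an aromatic carbon. Among the compounds with values here, the only measured step, a 1.2-fold higher number from compound 1 to compound 2 (0.07 log units; within the scatter), alters the anilino group that is now exchanged, but it adds to that group rather than replacing it, and it stayed within the scatter. Within the data shown here, no measured pair shows what exchanging anilino for 4-methylpiperidin-1-yl does at this place, so the expectation can rest only on how little the three numbers move. The step of a 1.1-fold lower number from compound 1 to compound 4 (0.03 log units; within the scatter) is what is expected, with no shift beyond the scatter. Compound 4 is estimated at 1000 nM, within a range from 400 nM to 2500 nM.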

Compound 4, half-maximal inhibitory concentration: 950 nM
The estimate for compound 4 lay 1.1-fold (0.02 log units) above the measured number; the range from low to high includes it.
By their numbers in this assay, from the lowest: compounds 4, 3, 1 and 2 (each within the scatter of the next).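

Until now, the anilino group at this place had only been added to, whereas compound 4 replaces it outright, swapping a six-membered aromatic ring of carbon only for a six-membered non-aromatic ring and removing the hydrogen-bond donor of the anilino group while keeping the same count of heavy atoms. Even so, in this assay the result is a 1.1-fold lower number from compound 1 to compound 4 (0.05 log units; within the scatter), so for this pair neither the aromatic ring of the anilino group nor its hydrogen-bond donor is required to keep the number where it stands, at this aromatic carbon next to the ring nitrogen. Nothing measured here explains why the number holds so steady through so large a change in the group.

The compounds shown leave open whether any group at this place can move the number beyond the scatter, for instance a small primary amine, a morpholine ring or a chain ending in a carboxylic acid. They also leave open whether the same exchange of anilino for 4-methylpiperidin-1-yl would behave alike on the core of compound 3.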